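A few compounds are considered here, and "the series" means these few. Any claim that something is new, unique, unknown or untested is made for them only; others in the source may bear on it.

Three compounds have been measured so far in an ADME assay on the whole organism (blood, Mus musculus, strain C57BL/6) for pharmacokinetics, read by HPLC, with a stated time of 4 h, at a dose of 2 mg/kg by the intraperitoneal route; a lower number here means less compound in the circulation, a higher number more compound in the circulation at the dose given:

Compound 1 `CN1CCN(S(=O)(=O)c2c(Cl)ccc(NC(=O)Nc3cccc(Cl)c3Cl)c2O)CC1`: 303 ng.h/mL
Compound 2 `CC(C)S(=O)(=O)c1c(Cl)ccc(NC(=O)Nc2cccc(Cl)c2Cl)c1O`: 290 ng.h/mL
Compound 3 `C[C@@H]1CN(S(=O)(=O)c2c(Cl)ccc(NC(=O)Nc3cccc(Cl)c3Cl)c2O)C[C@H](C)O1`: 519 ng.h/mL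

Compound 3 stands within the scatter of both other compounds. The two steps that reach it are a 1.7-fold higher number from compound 1 to compound 3 (0.23 log units; within the scatter) and a 1.8-fold higher number from compound 2 to compound 3 (0.25 log units; within the scatter), and the remaining step is a 1.0-fold lower number from compound 1 to compound 2 (0.02 log units; within the scatter). All three are changes of the group on the sulfonyl sulfur, and none of them leaves the scatter.

Compound 4 `CCS(=O)(=O)c1c(Cl)ccc(NC(=O)Nc2cccc(Cl)c2Cl)c1O` differs from compound 3 in one place: ethyl in place of 2,6-dimethylmorpholin-4-yl on a sulfonyl sulfur. This exact change has not been measured. The closest measured step replaces the same 2,6-dimethylmorpholin-4-yl with isopropyl rather than ethyl, and it is a 1.8-fold higher number from compound 2 to compound 3 (0.25 log units; within the scatter) when read in the opposite direction. With only these three small steps to go on, no step beyond the scatter is expected in this assay, though the value is expected to lean towards that of compound 2 at 290 ng.h/mL and thus to the lower side of compound 3.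

The estimated value for compound 4 is 300 ng.h/mL, with an expected range from 140 ng.h/mL to 640 ng.h/mL.

This estimate means an expected 1.7-fold lower number from compound 3 to compound 4 (0.24 log units; within the scatter).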

Compound 4, area under the concentration-time curve: 256 ng.h/mL
Compound 4: middle estimate off by 1.2-fold (0.07 log units), on the high side, and the stated range covers the measured number.
By their numbers in this assay, from the lowest: compounds 4, 2, 1 and 3 (each within the scatter of the next, the first and the last beyond it).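

In this assay, among these compounds, ethyl in place of 2,6-dimethylmorpholin-4-yl on a sulfonyl sulfur gives the only step at this position that lies beyond the scatter (a 2.0-fold lower number from compound 3 to compound 4 (0.31 log units; beyond the scatter)), and it is a modest one. The two other new steps stay within the scatter, both hydrogen in place of methyl on the isopropyl group (a 1.1-fold lower number from compound 2 to compound 4 (0.05 log units; within the scatter)) and ethyl in place of 4-methylpiperazin-1-yl (a 1.2-fold lower number from compound 1 to compound 4 (0.07 log units; within the scatter)), so ethyl, isopropyl and 4-methylpiperazin-1-yl cannot be told apart here, and compound 3 separates only from compound 4 while remaining within the scatter of compound 1 and compound 2. Nothing measured alongside these numbers bears on what lies behind this step.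

The compounds shown leave open whether a plain morpholin-4-yl, without the methyl groups, would read like compound 3 or like compound 4, and whether the two defined stereocentres of compound 3 play any part. They also leave open how a longer chain such as n-butyl, or a carboxylic acid carried on that chain, would read on the sulfonyl sulfur in this assay.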